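This account rests on a few compounds, and the source may have more. Where it says the series, first, only, none or still open, it means among the compounds named here.

Values so far in a functional assay on A549 cells (Homo sapiens) for inhibition, read by MTT assay, with a stated time of 72 h; on this read-out higher numbers stand for weaker inhibition and lower numbers for stronger inhibition
compound 1 `C=CC(=O)Nc1cc(Nc2nc3c(c(-c4cn(C)c5ccc(F)cc45)n2)CS(=O)(=O)CC3)c(OC)cc1N(C)CCN(C)C` at 4640 nM
compound 2 `COc1cc(N(C)CCN(C)C)c(NC(=O)C=C(C)C)cc1Nc1nc2c(c(-c3cn(C)c4ccc(F)cc34)n1)CS(=O)(=O)CC2` at 2140 nM

Compound 2 holds the lower of the two numbers, at 2140 nM and with no other comparison available. Compound 3 `C/C=C\C(=O)Nc1cc(Nc2nc3c(c(-c4cn(C)c5ccc(F)cc45)n2)CS(=O)(=O)CC3)c(OC)cc1N(C)CCN(C)C` differs from compound 2 by one change: prop-1-en-1-yl in place of 2-methylprop-1-en-1-yl on a carbonyl carbon. Among the compounds with values here, one measured step bears on this, the modest 2.2-fold lower number from compound 1 to compound 2 (0.34 log units; beyond the scatter) on replacing vinyl with 2-methylprop-1-en-1-yl. The entering group has no measured value yet, so a small move towards weaker inhibition is expected, possibly inside the scatter. Expected in this assay is a 1.4-fold higher number from compound 2 to compound 3 (0.15 log units; within the scatter) (no larger than the measured step). Compound 3 is estimated at 3000 nM (range 1500 nM to 6000 nM).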

Compound 3, half-maximal inhibitory concentration: 3990 nM
Beside the measured number, compound 3's estimate is 1.3-fold (0.12 log units) below it, within the range that was stated.
By their numbers in this assay, from the lowest: compounds 2, 3 and 1 (each within the scatter of the next, the first and the last beyond it).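

In this assay prop-1-en-1-yl on the carbonyl carbon cannot be separated from either neighbouring group: a 1.9-fold higher number from compound 2 to compound 3 (0.27 log units; within the scatter) and a 1.2-fold lower number from compound 1 to compound 3 (0.07 log units; within the scatter) are both read as no clear change. Of the three steps, only a 2.2-fold lower number from compound 1 to compound 2 (0.34 log units; beyond the scatter) clears the scatter, so compound 3 sits within reach of both ends of this small set, and the data give no graded order for it. No measurement shown explains these numbers.
Left open is whether a longer chain or an amine on this carbonyl carbon would move the number in this assay beyond the scatter of these compounds.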